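A few compounds are considered here, and "the series" means these few. Any claim that something is new, unique, unknown or untested is made for them only; others in the source may bear on it.

Measured in a functional assay on cells for agonist activity at Free fatty acid receptor 1 (Homo sapiens), read by FLIPR and calcium flux, with a stated time of 100 s; on this read-out higher numbers stand for an effect only at larger amounts of compound and lower numbers for an effect already at smaller amounts:
compound 1 `O=C(O)C[C@@H]1CCCN1c1ccc(OCc2ccc(Cl)cc2Cl)cc1` gives 340 nM
compound 2 `Cc1cc(OCc2ccc(Cl)cc2Cl)ccc1N1CCC[C@H]1CC(=O)O` gives 8900 nM
compound 3 `Cc1ccccc1Oc1ccc(N2CCC[C@H]2CC(=O)O)cc1` gives 74 nM

Compound 3 has the lowest number of the three; the difference between its core and the core of compound 2 is not broken down here.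

One change recurs in the set. From compound 2 to compound 1 it is hydrogen in place of methyl on an aromatic carbon and gave a 26-fold lower number from compound 2 to compound 1 (1.42 log units; beyond the scatter). From compound 3 to compound 4 `O=C(O)C[C@@H]1CCCN1c1ccc(Oc2ccccc2)cc1`, not yet measured, it is hydrogen in place of methyl on an aromatic carbon. The change is of the same kind but not the same: in compound 2 the methyl sits ortho to a group of 9 heavy atoms and meta to a large group, in compound 3 it sits ortho to a large group on the other ring. A large step from compound 2 to compound 1 therefore does not fix the size of the step here; the expectation is a smaller, uncertain one, a 1.6-fold higher number from compound 3 to compound 4 (0.21 log units; within the scatter), estimated from compound 3 at 74 nM in this assay. The expected value for compound 4 is 120 nM, between 35 nM and 400 nM.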

Compound 4, half-maximal effective concentration: 560 nM
For compound 4 the middle estimate is 4.7-fold (0.67 log units) below the measured one; measured number above the stated range.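

On the core of compound 3, hydrogen in place of methyl ortho to a large group costs activity in this assay, with a 7.6-fold higher number from compound 3 to compound 4 (0.88 log units; beyond the scatter). Set beside the earlier step, the same exchange runs in the opposite direction, and the two results are clearly different: the same change on two cores in this assay, a 26-fold lower number (1.42 log units; beyond the scatter) from compound 2 to compound 1 and a 7.6-fold higher number (0.88 log units; beyond the scatter) from compound 3 to compound 4, 200-fold (2.30 log units) apart, beyond the scatter of two such steps In this series, then, neither the size nor the direction of the methyl-to-hydrogen step can be carried from one core to the other, although two pairs show only that it did not carry here and give no general rule or cause, and the methyl also stands in a different place in each pair, so core and place cannot be separated.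

Open, on these data alone, is whether the gain from the methyl of compound 3 is specific to that group, or whether an ethyl, a methoxy or a fluorine at the same place would give a similar number. Also open, as far as these compounds go, is whether the step would keep its direction on the core of compound 3 if a tetrazole replaced the carboxylic acid.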